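Switch of the amide-bound chain on compound 1

The source may hold more compounds than are shown below. What is called first, only, known or untested is meant among the compounds shown, and "the series" means these compounds.

Compound 1 `CNCC(=O)N1CCN(CCCOc2ccc(C(=O)C3CC3)cc2)CC1` gives 79400 nM in an assay for binding affinity to histamine H2 receptor (Homo sapiens) (a higher number here means a weaker inhibitor, a lower number a stronger inhibitor), the highest of the two numbers available. Among the compounds with values here, compound 2 `CCCCCC(=O)c1ccc(OCCCN2CCN(C(=O)[C@H](CC(C)C)NC(=O)OC(C)(C)C)CC2)cc1` gives 3470 nM in this assay; the two values lie well beyond the scatter, and no single-point step connects them. Compound 3 `C[C@@H](NC(=O)OC(C)(C)C)C(=O)N1CCN(CCCOc2ccc(C(=O)C3CC3)cc2)CC1` differs from compound 1 by 1-((tert-butoxycarbonyl)amino)ethyl in place of (methylamino)methyl on a carbonyl carbon. Within the data shown here, no measured step covers this change; a decrease is expected because compound 2, carrying a related carbamate-bearing amide substituent, gives 3470 nM, although compound 2 also differs in its ketone chain. Compound 3 is therefore estimated at 12000 nM, within 3000 nM to 45000 nM, an expected step of a 6.6-fold lower number from compound 1 to compound 3 (0.82 log units; beyond the scatter).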

Compound 3, inhibition constant: 83200 nM
Beside the measured number, compound 3's estimate is 6.9-fold (0.84 log units) below it, outside the stated range (above it).
By their numbers in this assay, from the lowest: compound 2; then compounds 1 and 3 (each within the scatter of the next).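

In this assay, 1-((tert-butoxycarbonyl)amino)ethyl in place of (methylamino)methyl on this carbonyl carbon leaves the number within the scatter (a 1.0-fold higher number from compound 1 to compound 3 (0.02 log units; within the scatter)). With the rest of compound 1 unchanged, this carbamate-bearing group, with its defined stereocentre and larger heavy-atom count, therefore gives no measurable shift at this position. No measured evidence accounts for this flat result.

As far as these compounds go, whether a free primary amine or a carboxylic acid at this position would shift the number remains open. From the compounds shown here alone, compound 2 differs from compound 3 in more than one place, so the separate contribution of its longer ketone chain also remains open.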